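Methoxy substitution on two inactive cores: antiproliferative notes

A few compounds are considered here, and "the series" means these few. Any claim that something is new, unique, unknown or untested is made for them only; others in the source may bear on it.

Compound 1 `CCN1C(=O)S/C(=C\C2=Cc3ccccc3OC2)C1=O` carries an ethyl group on the shared core. In a functional assay on A549 cells (Homo sapiens) for antiproliferative activity, read by MTT assay, with a stated time of 72 h (a higher number here means a weaker inhibitor, a lower number a stronger inhibitor), compound 1 gives > 200000 nM, which is a limit of the assay and not a number. Compound 3 `CCN1C(=O)S/C(=C\C2=Cc3cccc(OC)c3OC2)C1=O` differs from compound 1 by methoxy in place of hydrogen on an aromatic carbon. In this assay compound 3 gives > 200000 nM, again a limit rather than a number. The step that the two limits leave unreadable from compound 1 to compound 3 cannot be read because the limit of > 200000 nM in this assay, at which 2 of the 3 values shown sit, holds both of these compounds, so the size of the change is unknown. Compound 2 `O=C(O)CN1C(=O)/C(=C/C2=Cc3ccccc3OC2)SC1=S` has a different core; the difference between the two cores is not broken down here. In this assay compound 2 gives > 100000 nM, once more a limit and not a number. Compound 2 stands at the limit of > 100000 nM in this assay, at which 1 of the 3 values shown sits, and nothing more than that can be said of it.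

Compound 4 `COc1cccc2c1OCC(/C=C1\SC(=S)N(CC(=O)O)C1=O)=C2` is not yet measured and differs from compound 2 by methoxy in place of hydrogen on an aromatic carbon. For the measured compounds named here, this is the same change as the one from compound 1 to compound 3, made at the same place on the six-membered aromatic ring of carbon only. The expectation for compound 4 rests on the step that the two limits leave unreadable from compound 1 to compound 3, where the same change left the reading at a limit. The expected step is a step that the limit leaves unreadable from compound 2 to compound 4, beside that earlier unreadable one. Compound 4 is expected to give 150000 nM, with an estimated range from 50000 nM to 400000 nM, and a limit rather than a number is the most likely outcome.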

Compound 4, half-maximal inhibitory concentration: > 200000 nM
Compound 4 was reported as a limit; the forecaster's own chance of this, stated with the estimate: 85%; at least 1.3-fold (0.12 log units) between middle value and limit.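

In this assay, for the compounds shown here, compound 2 and compound 4 both stand at limits of the assay and not at numbers, and no step between them can be read. Compound 4 sits at a limit shared with other compounds: the limit of > 200000 nM in this assay, at which 3 of the 4 values shown sit.

The compounds shown leave open whether methoxy in place of hydrogen on an aromatic carbon changes antiproliferative activity on either core.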